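One halogen for another on a shared core

A few compounds are considered here, and "the series" means these few. Any claim that something is new, unique, unknown or untested is made for them only; others in the source may bear on it.

Compound 1 `O=C(/C=C/c1ccc([N+](=O)[O-])o1)c1ccc(Br)cc1` was tested in an ADME assay on THP-1 cells (Homo sapiens) for cytotoxicity, read by resazurin assay, with a stated time of 72 h (a higher number here means that more compound is tolerated, a lower number that less compound is tolerated), where compound 1 gives 13400 nM. Among the two plain numbers recorded, this is the higher one, yet it cannot be ranked against its nearest neighbour, compound 3 `CSc1ccc(C(=O)/C=C/c2ccc([N+](=O)[O-])s2)cc1`, which gives 8560 nM in this assay, a gap that lies within the usual scatter. Compound 2 `O=C(/C=C/c1cccc([N+](=O)[O-])c1)c1ccc(N2CCCCC2)cc1` gave > 50000 nM in this assay, which is a limit of the assay and not a number. That value is the limit of > 50000 nM in this assay, at which 1 of the 3 values shown sits.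

Compound 4 `O=C(/C=C/c1ccc([N+](=O)[O-])o1)c1ccc(I)cc1` differs from compound 1 in a single place: iodo in place of bromo on an aromatic carbon. Within the data shown here, none of the measured compounds form a pair that differs only in this way, so no measured step can be borrowed to size the change. Given that the change leaves the rest of the molecule untouched and alters a single heavy atom, the expectation is a step that stays within the scatter, with no clear direction.

On that basis, compound 4 is estimated to give 12000 nM in this assay, with a likely range from 5000 nM to 30000 nM. This estimate corresponds to an expected 1.1-fold lower number from compound 1 to compound 4 (0.05 log units; within the scatter), that is, essentially no change beyond the noise of the measurement.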

Compound 4, half-maximal cytotoxic concentration: 49500 nM
Beside the measured number, compound 4's estimate is 4.1-fold (0.62 log units) below it; measured number above the stated range.
By their numbers in this assay, from the lowest: compounds 3 and 1 (each within the scatter of the next); then compound 4. At a limit, above all of these: compound 2.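

The step is the first single-place comparison among these compounds, and it shows that this position, on a six-membered aromatic ring of carbon only and para to a large group, is sensitive to which halogen it carries: in this assay, iodo in place of bromo gives a 3.7-fold higher number from compound 1 to compound 4 (0.57 log units; beyond the scatter). Neither group brings a ring, a hydrogen-bond donor or acceptor, or a net charge, yet replacing one heavy atom with another is enough to move the result beyond the scatter, towards more compound being tolerated. Nothing shown here accounts for the size or direction of this step.

The compounds shown carry only bromo and iodo at this place on the shared core, so it remains open how chloro, fluoro, an amine or a carboxylic acid would stand there in this assay. Going by these compounds, it also remains open whether the same change would give a similar step on the cores of compound 2 and compound 3, since neither has a partner here that differs from it in one place.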